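The compounds below may be only part of what the source reports. "The series", "measured", "known", "first", "only" and "open" are said of these compounds alone.

Measured in a functional assay on NT2 cells (Homo sapiens) for inhibition; a higher number here means a weaker inhibitor, a lower number a stronger inhibitor:
- compound 1 `CC[C@@H](C(=O)N[C@@H](CC(=O)O)C(=O)CSCc1ccccc1)n1cccc(NC(=O)[C@H](CC(=O)O)NC(C)=O)c1=O`: 5.2 nM
- compound 2 `CCCCCCN(C)CNCC(=O)[C@H](CC(=O)O)NC(=O)C(CC)n1cc(C(C)(CC)CC)nc(NCc2nonc2C)c1=O`: 0.025 nM

Of these two, compound 1 stands at 5.2 nM and compound 2 at 0.025 nM. The gap between them lies well beyond the scatter, with compound 2 holding the lower number. Compound 3 `CCCCCCN(C)CNCC(=O)[C@H](CC(=O)O)NC(=O)C(CC)n1ccnc(NCc2nonc2C)c1=O` carries a single change from compound 2: hydrogen in place of 1-ethyl-1-methylpropyl on an aromatic carbon. Within the data shown here, no measured pair shows this change, so the expectation rests on judgement alone: a moderate move to a higher number in this assay, beyond the scatter. The expected step is a 6.0-fold higher number from compound 2 to compound 3 (0.78 log units; beyond the scatter). For compound 3 the estimated value is 0.15 nM, with an expected range from 0.03 nM to 0.8 nM.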

Compound 3, half-maximal inhibitory concentration: 0.13 nM
Beside the measured number, compound 3's estimate is 1.2-fold (0.06 log units) above it; measured number inside the range.
By their numbers in this assay, from the lowest: compound 2; then compound 3; then compound 1.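

In this assay, replacing the 1-ethyl-1-methylpropyl group on this aromatic carbon, next to the ring nitrogen, with hydrogen gives a 5.2-fold higher number from compound 2 to compound 3 (0.72 log units; beyond the scatter). The step is modest, so at this position the six-carbon group lowers the number but is not required for inhibition in the low range seen for compound 3. Nothing shown explains the step. This single pair leaves open how a methyl, an ethyl or an amine on the same carbon would compare, and so whether the number follows the size of the group.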